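The source may hold more compounds than are shown below. What is called first, only, known or untested is meant among the compounds shown, and "the series" means these compounds.

Values measured in a functional assay on HT-29 cells (Homo sapiens) for inhibition, read by sulforhodamine B assay, with a stated time of 96 h (on this read-out lower numbers stand for stronger inhibition of growth and higher numbers for weaker inhibition of growth), so far:
compound 1 `CC[C@@H](Nc1nc(NCc2ccccn2)c2ncn(C(C)C)c2n1)C(C)(C)O` gives > 50000 nM as a limit
compound 2 `CC[C@@H](Nc1nc(NCc2ccccn2)c2ncn(C(C)C)c2n1)C(C)O` gives 42000 nM as a number
compound 3 `CCC(O)[C@@H](CC)Nc1nc(NCc2ccccn2)c2ncn(C(C)C)c2n1` gives > 50000 nM as a limit

Compound 3 stands at > 50000 nM which is a limit and not a number. The same limit is shared within the series, as the limit of > 50000 nM in this assay, at which 2 of the 3 values shown sit, records.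

The next change leads to compound 4 `CC[C@@H](Nc1nc(NCc2ccccn2)c2ncn(C(C)C)c2n1)C(O)C(C)(C)C` and reads tert-butyl in place of ethyl on a saturated chain carbon bound to an oxygen on a saturated carbon and a saturated chain carbon in the side chain.

Going by the values given here, three measured steps bear on it. Two are an at least 1.1-fold lower number from compound 1 to compound 2 (0.07 log units; that floor lies within the scatter) and an at least 1.1-fold higher number from compound 2 to compound 3 (0.07 log units; that floor lies within the scatter) and both have floors within the scatter. The third is a step that the two limits leave unreadable from compound 1 to compound 3 and gives no readable size. Among the compounds with values here, none of them shows a chain change moving this assay beyond the scatter, so no step of readable size is expected here. The expected step is a number no higher from compound 3 to compound 4 (the limit leaves the size open) and this remains an estimate.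

For compound 4 the estimated value is 50000 nM with an expected range from 18000 nM to 100000 nM in this series.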

Compound 4, concentration for 50% growth inhibition: 34000 nM
Compound 4: middle estimate off by 1.5-fold (0.17 log units), on the high side; the range from low to high includes it.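

In this assay, tert-butyl on this saturated chain carbon gives a number where the ethyl of compound 3 gave only a limit, and the step reads an at least 1.4-fold lower number from compound 3 to compound 4 (0.16 log units; that floor lies within the scatter). Against methyl at the same place the step is a 1.2-fold lower number from compound 2 to compound 4 (0.09 log units; within the scatter), so even with the larger chain on this carbon, compound 2 and compound 4 cannot be told apart. The change from 1-hydroxy-1-methylethyl to 1-hydroxy-2,2-dimethylpropyl reads an at least 1.4-fold lower number from compound 1 to compound 4 (0.16 log units; that floor lies within the scatter), and like the step from compound 3 it is only a floor set by a limit.

From the compounds shown here alone, how far compound 1 and compound 3 truly lie from compound 4 stays open, and both rest on one shared ceiling: the limit of > 50000 nM in this assay, at which 2 of the 4 values shown sit. Whether an amine or a carboxylic acid on this carbon would move the value beyond the scatter also stays open.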